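The compounds below may be only part of what the source reports. "The series", "measured", "known", "first", "only" and "open" are said of these compounds alone.

Measured so far:
Compound 1, `CC(C)OC(=O)N1CCC(Oc2ncnc3c2CCN3c2ccc(S(C)(=O)=O)cc2F)CC1`: 91%
Compound 2, `CC(C)OC(=O)N1CCC(Oc2ncnc3c2CCN3c2ccc(C#N)c(F)c2)CC1`: 121%

Both were tested in a functional assay on CHO-K1 cells with Glucose-dependent insulinotropic receptor (Homo sapiens) as the target, read by a luciferase reporter, with a stated time of 5 h; a higher number here means a larger maximal response, a lower number a smaller maximal response. Compound 2 stands highest of the two numbers; its nearest neighbour is compound 1, and the step of a number 30 percentage points higher from compound 1 to compound 2 (beyond the scatter) lies beyond the scatter. Compound 3, `CC(C)OC(=O)N1CCC(Oc2ncnc3c2CCN3c2ccc([S@@+](C)[O-])c(F)c2)CC1`, has not yet been measured in this assay. It differs from compound 2 in one place: a group of 3 heavy atoms (1 carbon, 1 oxygen, 1 sulfur; no ring) in place of a group of 2 heavy atoms (1 carbon, 1 nitrogen; no ring), on an aromatic carbon. Going by the values given here, the only measured step that bears on this change is the one from compound 1 to compound 2, where a sulfur-bearing group gave way to a cyano group and the number rose modestly. Compound 3 brings a sulfur-bearing group back, though a different one, so part of that rise is expected to be given back because a number 30 percentage points higher from compound 1 to compound 2 (beyond the scatter) went the other way. The step of a number 21 percentage points lower from compound 2 to compound 3 (beyond the scatter) is therefore expected to be downward and modest. For compound 3 the estimate is 100%, within 75% to 125%.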

Compound 3, largest response reached (reported as percent of maximum), in percent of the reference or control that the assay uses: 155%
The estimate for compound 3 lay 55 percentage points below the measured number, outside the stated range (above it).
By their numbers in this assay, from the lowest: compound 1; then compound 2; then compound 3.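

In this assay the group on this aromatic carbon can raise the maximal response well past the level seen with cyano: swapping cyano for the sulfur-bearing group of three heavy atoms gives a number 34 percentage points higher from compound 2 to compound 3 (beyond the scatter). Sulfur alone does not set the number, since changing the whole fluorinated aryl group on the ring nitrogen of compound 1 gives a number 64 percentage points higher from compound 1 to compound 3 (beyond the scatter), and compound 2, which has no sulfur, falls between these two sulfur-bearing compounds. No measurement here explains why these groups differ.

On these data alone, the entering group carries a defined stereocentre, so it remains open whether the opposite arrangement at that centre gives a similar response. As far as these compounds go, how an amine or a carboxylic acid on this aromatic carbon would read also remains open.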